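Ester variation and plasma half-life in a bicyclic diester series

This account rests on a few compounds, and the source may have more. Where it says the series, first, only, none or still open, it means among the compounds named here.

Measured compounds:
compound 1 `CC(=O)Oc1ccccc1C(=O)O[C@H]1CO[C@H]2[C@@H]1OC[C@H]2OC(=O)c1ccnn1C` gives 0.0963 h
compound 2 `CC(=O)Oc1ccccc1C(=O)O[C@H]1CO[C@H]2[C@@H]1OC[C@H]2OC(=O)c1ccccc1` gives 0.055 h
compound 3 `CC(=O)Oc1ccccc1C(=O)O[C@H]1CO[C@H]2[C@@H]1OC[C@H]2OC(=O)c1ccc(-c2ccccc2)cc1` gives only a limit of the assay, > 0.333 h

In an ADME assay on a cell-free system (plasma, Homo sapiens) for metabolic stability, with Plasma (Rattus norvegicus) as the target, read by HPLC, at pH 7.4 (a higher number here means that the compound lasts longer, a lower number that the compound disappears faster), compound 2 stands lowest of the two plain numbers, and the step of a 1.8-fold lower number from compound 1 to compound 2 (0.24 log units; within the scatter) stays within the scatter. Compound 3 sits at a limit of the assay. Within the data shown here, the step of an at least 6.0-fold higher number from compound 2 to compound 3 (0.78 log units; beyond the scatter) is the one change here that clearly lengthens the half-life. Compound 4 `CC(=O)Oc1ccccc1C(=O)O[C@H]1CO[C@H]2[C@@H]1OC[C@H]2OC(=O)c1cc(C)nc(Cl)c1` differs from compound 2 by 2-chloro-6-methylpyridin-4-yl in place of phenyl on a carbonyl carbon. Swapping one aromatic ester ring for another moved little, as a 1.8-fold lower number from compound 1 to compound 2 (0.24 log units; within the scatter) shows, whereas enlarging the ring system mattered, as an at least 6.0-fold higher number from compound 2 to compound 3 (0.78 log units; beyond the scatter) shows; a 2-chloro-6-methylpyridin-4-yl ring adds bulk but no second ring. Compound 4 is therefore expected at 0.09 h (range 0.04 h to 0.25 h), a step of a 1.6-fold higher number from compound 2 to compound 4 (0.21 log units; within the scatter) expected to stay near the scatter.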

Compound 4, half-life: 0.0193 h
For compound 4 the middle estimate is 4.7-fold (0.67 log units) above the measured one; the measured number lies below the stated range.
By their numbers in this assay, from the lowest: compound 4; then compounds 2 and 1 (each within the scatter of the next). At a limit, above all of these: compound 3.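

In this assay, exchanging one single aromatic ring for another on this carbonyl carbon can matter: with 2-chloro-6-methylpyridin-4-yl there is a 2.8-fold lower number from compound 2 to compound 4 (0.45 log units; beyond the scatter) and a 5.0-fold lower number from compound 1 to compound 4 (0.70 log units; beyond the scatter), so no second ring is needed for a change beyond the scatter. The gap to the 4-phenylphenyl ester is wider still, with an at least 17-fold lower number from compound 3 to compound 4 (1.23 log units; beyond the scatter). That last step rests on a limit: the limit of > 0.333 h in this assay, at which 1 of the 4 values shown sits.

The compounds shown leave open whether the chlorine, the methyl or the ring nitrogen accounts for the shorter half-life. As far as these compounds go, how an amine or a carboxylic acid on this ring would behave also remains open.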